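The source may hold more compounds than are shown below. What is called first, only, known or untested is meant among the compounds shown, and "the series" means these compounds.

Measured in an ADME assay on the whole organism (Rattus norvegicus, strain Sprague-Dawley) for metabolic stability, read by LC-MS, with a stated time of 48 h, at a dose of 5 mg/kg by the intravenous route; on this read-out higher numbers stand for a longer-lived compound and lower numbers for a shorter-lived compound:
- compound 1 `CC#CCn1c(N2CCC[C@@H](N)C2)nc2c1c(=O)n(Cc1cc(Cl)ccc1C(=O)O)c(=O)n2C`: 0.82 h
- compound 2 `CC#CCn1c(N2CCC[C@@H](N)C2)nc2c1c(=O)n(Cc1ccc(Br)cc1C(=O)O)c(=O)n2C`: 5.75 h

Compound 2 holds the higher of these two numbers, and the gap to compound 1 lies beyond the scatter. The next case is compound 3 `CC#CCn1c(N2CCC[C@@H](N)C2)nc2c1c(=O)n(Cc1cc(OC)ccc1C(=O)O)c(=O)n2C`, which is still unmeasured. The change is 2-carboxy-5-methoxyphenyl in place of 4-bromo-2-carboxyphenyl on a saturated chain carbon bound to an aromatic nitrogen.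

For the measured compounds named here, only one measured step bears on this change. It is a 7.0-fold higher number from compound 1 to compound 2 (0.85 log units; beyond the scatter), a modest step beyond the scatter, in which 4-bromo-2-carboxyphenyl replaces 2-carboxy-5-chlorophenyl. The group entering compound 3 has the same numbering in its name as the group of compound 1, which gives 0.82 h. Going by the values given here, no measured compound carries the methoxy group, however, so this comparison is only a rough guide. A fall in this assay is therefore expected, probably somewhat smaller than the measured step, and the expected step is a 3.6-fold lower number from compound 2 to compound 3 (0.56 log units; beyond the scatter). For compound 3 the estimated half-life is 1.6 h, with an expected range from 0.6 h to 4.5 h.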

Compound 3, half-life: 0.26 h
The estimate for compound 3 lay 6.2-fold (0.79 log units) above the measured number, outside the stated range (below it).
By their numbers in this assay, from the lowest: compound 3; then compound 1; then compound 2.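

In this assay, 2-carboxy-5-methoxyphenyl in place of 4-bromo-2-carboxyphenyl gives a 22-fold lower number from compound 2 to compound 3 (1.34 log units; beyond the scatter), a large step that shows the substituted ring on this saturated chain carbon can move the half-life further than the earlier pair alone revealed. With the numbering in the group's name held the same, methoxy in place of chloro on an aromatic carbon gives a 3.2-fold lower number from compound 1 to compound 3 (0.50 log units; beyond the scatter), also beyond the scatter, so the identity of the substituent matters on its own, whereas the earlier pair changed the halogen and its numbering together. No accompanying measurement accounts for these differences in half-life.

The compounds shown leave open whether the high number of compound 2 belongs to the bromine or to its numbering in the group's name, a question that 5-bromo-2-carboxyphenyl and 4-chloro-2-carboxyphenyl would separate. On these data alone, it also remains open how a fluoro, hydroxy or amino group would read on the same aromatic carbon, and whether 2-carboxy-4-methoxyphenyl would follow the bromo or the methoxy compound.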